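The compounds below may be only part of what the source reports. "The series", "measured", "known", "first", "only" and "open" are said of these compounds alone.

Compound 1, `C[Se]/C(=N\C(=O)c1cc2ccccc2s1)NC(=O)c1cc2ccccc2s1`, in a functional assay on PC-3 cells (Homo sapiens) for cytotoxicity, read by MTT assay, with a stated time of 72 h (on this read-out lower numbers stand for stronger inhibition of growth and higher numbers for weaker inhibition of growth), gives 37200 nM.
Compound 2, `C[Se]/C(=N\C(=O)c1ccco1)NC(=O)c1ccco1`, gives 360 nM.
Compound 3, `CS/C(=N\C(=O)c1cc2ccccc2s1)NC(=O)c1cc2ccccc2s1`, gives 8580 nM.

Compound 3 stands second highest of the three numbers in this assay: compound 1 sits beside it with a higher number, and compound 2, whose core differs from the other two, sits far below it with the lowest number of the set.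

The next compound, compound 4, is `O=C(/N=C(/NC(=O)c1cc2ccccc2s1)[Se]Cc1ccccc1)c1cc2ccccc2s1`. It differs from compound 3 in one place: a group of 8 heavy atoms (7 carbon, 1 selenium; one six-membered aromatic ring of carbon only) in place of a group of 2 heavy atoms (1 carbon, 1 sulfur; no ring), on a carbon with a double bond to nitrogen.

Among the measured compounds shown here, only one measured step touches this position. Going from compound 1 to compound 3, a sulfur took the place of a selenium on that carbon, and the number fell: a 4.3-fold lower number from compound 1 to compound 3 (0.64 log units; beyond the scatter). Compound 4 reverses that exchange, putting selenium back, and at the same time replaces the methyl with a larger group carrying a six-membered aromatic ring. No measured pair shows what the larger group does on its own, so that part of the change is unsupported by the numbers shown. Because a 4.3-fold lower number from compound 1 to compound 3 (0.64 log units; beyond the scatter) went against selenium, compound 4 is expected to come out with a higher number than compound 3, a step of roughly a 2.3-fold higher number from compound 3 to compound 4 (0.37 log units; beyond the scatter), with wide uncertainty from the untested benzyl part. Compound 4 is therefore estimated at 20000 nM, within a range from 5000 nM to 80000 nM.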

Compound 4, concentration for 50% growth inhibition: 30500 nM
Compound 4: the middle estimate sits 1.5-fold (0.18 log units) below what was measured; low and high end bracket the measured number.
By their numbers in this assay, from the lowest: compound 2; then compound 3; then compounds 4 and 1 (each within the scatter of the next).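

Compound 4 pulls apart what the step from compound 1 to compound 3 could not: with selenium held in place, phenyl in place of hydrogen on a saturated chain carbon bound to a selenium atom gives a 1.2-fold lower number from compound 1 to compound 4 (0.09 log units; within the scatter) in this assay, so on this core the larger selenium group and the methyl one cannot be told apart. The full exchange on the carbon with a double bond to nitrogen gives a 3.6-fold higher number from compound 3 to compound 4 (0.55 log units; beyond the scatter), a step of similar size to a 4.3-fold lower number from compound 1 to compound 3 (0.64 log units; beyond the scatter), read in the opposite direction. Among these three compounds with the shared core, the two selenium compounds therefore stand together and sulfur compound 3 stands apart from them, and no measurement offered here speaks to why.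

Going by these compounds, whether a benzyl group on sulfur would keep the lower number of compound 3 remains open, as does whether selenium and sulfur differ in the same way on the core of compound 2. How a longer chain such as propyl, or an amine, would fare on this same carbon is also unknown.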